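The source may hold more compounds than are shown below. What is called first, only, known or untested is meant among the compounds shown, and "the series" means these compounds.

Working notes on the series.

Compound 1 `Nc1ccc(Nc2nc3ccccc3nc2S(=O)(=O)c2ccccc2)cc1` is the parent of the set. In a functional assay on HL-60 cells (Homo sapiens) for cytotoxicity, read by MTT assay, with a stated time of 72 h (a lower number here means a stronger inhibitor, a higher number a weaker inhibitor), compound 1 gives 8720 nM. Compound 2 `COc1ccc(S(=O)(=O)c2nc3ccccc3nc2Nc2ccc(N)cc2)cc1` differs from compound 1 by methoxy in place of hydrogen on an aromatic carbon, and in this assay compound 2 gives 710 nM. That single change produced a 12-fold lower number from compound 1 to compound 2 (1.09 log units; beyond the scatter), so the methoxy group on the ring of compound 2 brings a clearly stronger number than the unsubstituted ring of compound 1.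

Compound 3 `COc1cc(Nc2nc3ccccc3nc2S(=O)(=O)c2ccc(Br)cc2)cc(OC)c1` carries a different core from compound 1; the difference between the two cores is not broken down here. In this assay compound 3 gives 2540 nM, which lies between the numbers of compound 1 and compound 2.

Compound 4 `COc1cc(Nc2nc3ccccc3nc2S(=O)(=O)c2ccc(Br)cc2)cc(OC)c1OC` has not yet been measured. It differs from compound 3 by methoxy in place of hydrogen on an aromatic carbon. For the measured compounds named here, this is the same kind of change as the one from compound 1 to compound 2, but not the same: in compound 2 the entering methoxy sits para to a large group only, whereas in compound 4 it sits ortho to two methoxy groups and para to a large group, on a ring that already carries two methoxy groups. Going by the values given here, with only one measured example of this kind of change, and that on a ring without other methoxy groups, the earlier step is a weak guide. Compound 4 is expected to improve on compound 3 by less than the earlier step, with the expected step being a 1.7-fold lower number from compound 3 to compound 4 (0.23 log units; within the scatter), because compound 3 starts at 2540 nM and the earlier change from compound 1 to compound 2 gave a 12-fold lower number from compound 1 to compound 2 (1.09 log units; beyond the scatter) at a place that was not crowded by other methoxy groups. For compound 4 the estimate in this assay is 1500 nM, expected to fall between 500 nM and 4500 nM.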

Compound 4, half-maximal inhibitory concentration: 1020 nM
For compound 4 the middle estimate is 1.5-fold (0.17 log units) above the measured one, and the stated range covers the measured number.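

In this assay, methoxy in place of hydrogen on an aromatic carbon again goes with a lower number, with a 2.5-fold lower number from compound 3 to compound 4 (0.40 log units; beyond the scatter), so in these two pairs the direction of the change carries from one core to the other. The size does not carry over: the same change on two cores in this assay, a 12-fold lower number (1.09 log units; beyond the scatter) from compound 1 to compound 2 and a 2.5-fold lower number (0.40 log units; beyond the scatter) from compound 3 to compound 4, 4.9-fold (0.69 log units) apart, beyond the scatter of two such steps. This does not show what sets the size of the step, as the pairs differ both in core and in the surroundings of the entering methoxy, which joins a ring already carrying two methoxy groups in compound 4 and a ring with no other methoxy group in compound 2; the gap cannot be assigned to either difference, and two pairs set no rule for a further core.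

Still open, on these data alone, is whether methoxy would give a larger step on the core of compound 3 if it entered a ring with no other methoxy group, and whether the step on the core of compound 1 would shrink on a ring already carrying two methoxy groups. Also open, as far as these compounds go, is whether an ethoxy group, a hydroxyl group or an amine at the same place would give a step of similar size.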